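The source may report more compounds than this note shows. Statements on the series, on what has been measured and on what is new or still open speak of the compounds shown alone.

Working notes on the sulfonyl series.

Compound 1 `CC(O)(CS(=O)(=O)c1ccc(Cl)cc1)c1nc(-c2ccc([N+](=O)[O-])c(C(F)(F)F)c2)no1` is the reference point. In a functional assay on DU-145 cells (Homo sapiens) for cytotoxicity, read by MTT assay (a lower number here means a stronger inhibitor, a higher number a weaker inhibitor), compound 1 gives 91000 nM, the highest of the two numbers obtained in the set. Compound 3 `CC(O)(CS(=O)(=O)c1ccc(Br)cc1)c1nc(-c2ccc(F)c(Cl)c2)no1` is the nearest to it, with 75000 nM in this assay, and the gap between compound 1 and compound 3 stays within the usual scatter, so no order between the two can be stated. Compound 2 `CC(O)(CS(=O)(=O)c1ccc(F)cc1)c1nc(-c2ccc(Cl)cc2)no1` is not reported as a number in this assay: for compound 2 the read-out is a limit, > 100000 nM. That there is the limit of > 100000 nM in this assay, at which 1 of the 3 values shown sits, marks the top of the range this assay resolves.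

Among the compounds with values here, no pair of measured compounds differs in a single place, so no measured step is available to lean on.

Compound 4 `CC(O)(CS(=O)(=O)c1ccc(F)cc1)c1nc(-c2ccc([N+](=O)[O-])c(C(F)(F)F)c2)no1` is the untested member. Against compound 1 the change is fluoro in place of chloro on an aromatic carbon. Within the data shown here, with no measured step of this kind to hand, the expectation is that this exchange moves the number by no more than the scatter in this assay, in either direction. Compound 4 is therefore estimated at 100000 nM, with a range from 40000 nM to 250000 nM, which means an expected step of a 1.1-fold higher number from compound 1 to compound 4 (0.04 log units; within the scatter).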

Compound 4, half-maximal inhibitory concentration: > 100000 nM
Compound 4: no number, only a limit (the forecaster's own chance of this, stated with the estimate: 45%); the middle value sits exactly at the limit.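

Fluoro in place of chloro on this aromatic carbon is the first single-place step available in the series, and in this assay it reads as an at least 1.0-fold higher number from compound 1 to compound 4 (0.04 log units; that floor lies within the scatter). Compound 4 gives > 100000 nM, which is a limit and not a number. The step therefore has a floor but no upper bound, so this exchange at this position can be neither sized nor called silent, because compound 4 sits at the top of what the read-out resolves: the limit of > 100000 nM in this assay, at which 2 of the 4 values shown sit.

The compounds shown leave open whether any replacement at this aromatic carbon would give a value inside the resolved range, since a methoxy group, an amine or a plain hydrogen there is not among them. Also open is how the other end of the molecule, the aryl group on the shared core, behaves on its own, as no single-place step at that site is among the compounds shown.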